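Series notes: replacing the lysine-type side chain in compound 4

A few compounds are considered here, and "the series" means these few. Any claim that something is new, unique, unknown or untested is made for them only; others in the source may bear on it.

Compound 3 `NCCCC[C@H](NC(=O)CN(c1nc(Cl)nc2[nH]cnc12)C1CC1)C(=O)O` gives 11.6% in a functional assay on the whole organism (Tail, strain ICR) with Mus musculus as the target, in the tail flick test, with a stated time of 150 min, at a dose of 25 umol/kg by the oral route (on this read-out higher numbers stand for a stronger effect at the one dose given and lower numbers for a weaker effect), and stands second highest of the three numbers. Compound 1 `NC(=O)C[C@H](NC(=O)CN(c1nc(Cl)nc2[nH]cnc12)C1CC1)C(=O)O` gives 7.51%, a step of a number 4.1 percentage points higher from compound 1 to compound 3 (within the scatter), while compound 2 `O=C(O)CC[C@H](NC(=O)CN(c1nc(Cl)nc2[nH]cnc12)C1CC1)C(=O)O` gives 29.5%, a step of a number 17.9 percentage points lower from compound 2 to compound 3 (beyond the scatter). Compound 4 `CC(C)C[C@H](NC(=O)CN(c1nc(Cl)nc2[nH]cnc12)C1CC1)C(=O)O` is not yet measured; its change from compound 3 is isopropyl in place of 3-aminopropyl on a saturated chain carbon, two bonds along the chain from an amide-type nitrogen and a carbonyl carbon. Within the data shown here, no measured step introduces a side chain without donors or acceptors, so the two steps into compound 3 bear only loosely on it. The step of a number 2.4 percentage points higher from compound 3 to compound 4 (within the scatter) is expected to stay within the scatter. Compound 4 is estimated at 14%, with a range from 4% to 30%.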

Compound 4, a percentage reported as activity, at one dose (the size of the read-out at that dose, not a potency): 9.13%
The estimate for compound 4 lay 4.9 percentage points above the measured number; measured number inside the range.
By their numbers in this assay, from the lowest: compounds 1, 4 and 3 (each within the scatter of the next); then compound 2.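

Replacing a side chain that carries a hydrogen-bond donor and acceptor with isopropyl leaves the number in this assay within the scatter (a number 2.5 percentage points lower from compound 3 to compound 4 (within the scatter)), and the same holds for isopropyl in place of carbamoyl (a number 1.6 percentage points higher from compound 1 to compound 4 (within the scatter)). Carboxymethyl alone stands apart among the four side chains at this position (a number 20.4 percentage points lower from compound 2 to compound 4 (beyond the scatter)). No supporting data bear on the reason for this result.

As far as these compounds go, whether the number of compound 2 depends on the carboxylic acid itself stays open. A shorter or longer chain ending in a carboxylic acid, or a tetrazole on the same chain, would bear on this.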